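This account rests on a few compounds, and the source may have more. Where it says the series, first, only, none or still open, it means among the compounds named here.

In a physicochemical assay for solubility, in phosphate buffer, at pH 7.4 (on this read-out lower numbers stand for lower solubility and higher numbers for higher solubility), three compounds built on a shared core have been measured so far. Compound 1 `CCOC(=O)c1c(-c2ccccc2C)[nH]c2cc(OC)ccc2c1=O` gives > 100000 nM, which is a limit and not a number. Compound 2 `CCOC(=O)c1c(-c2cccc(F)c2)[nH]c2cc(OC)ccc2c1=O` gives > 100000 nM, which is also a limit. Going by the values given here, compound 3 `CCOC(=O)c1c(-c2ccc(Cl)c(Cl)c2)[nH]c2cc(OC)ccc2c1=O`, with its 3,4-dichlorophenyl group, gives 17000 nM, the only real number among the three. It stands lowest, with an at least 5.8-fold lower number from compound 1 to compound 3 (0.76 log units; beyond the scatter) and an at least 5.8-fold lower number from compound 2 to compound 3 (0.76 log units; beyond the scatter).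

Compound 4 `CCOC(=O)c1c(-c2ccc(Cl)cc2)[nH]c2cc(OC)ccc2c1=O` differs from compound 3 in one place: hydrogen in place of chloro on an aromatic carbon. Hydrogen takes the place of chloro, turning 3,4-dichlorophenyl into 4-chlorophenyl. Among the compounds with values here, no measured step makes exactly this change. The nearest guide is the step to 3,4-dichlorophenyl from 3-fluorophenyl, an at least 5.8-fold lower number from compound 2 to compound 3 (0.76 log units; beyond the scatter), and that step has only a lower bound on its size. Compound 4 keeps one chloro group, so undoing part of that step seems the fair reading, and a moderately higher number is expected. The expected step is a 2.9-fold higher number from compound 3 to compound 4 (0.47 log units; beyond the scatter). For compound 4 the estimated value is 50000 nM, with an expected range from 22000 nM to 100000 nM.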

Compound 4, solubility: 3000 nM
For compound 4 the middle estimate is 17-fold (1.22 log units) above the measured one; measured number below the stated range.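

In this assay, going by these compounds alone, hydrogen in place of chloro turns 3,4-dichlorophenyl into 4-chlorophenyl and gives a 5.7-fold lower number from compound 3 to compound 4 (0.75 log units; beyond the scatter), so the number falls where the earlier compounds gave no sign of it. The lowest number now belongs to the compound with one chloro group and not the one with two, so among these compounds more chloro does not go with a lower number. The gaps to the other two compounds are wider, an at least 33-fold lower number from compound 2 to compound 4 (1.52 log units; beyond the scatter) and an at least 33-fold lower number from compound 1 to compound 4 (1.52 log units; beyond the scatter), but these sizes are only minimums because compounds 1 and 2 each stop at a limit: the limit of > 100000 nM in this assay, at which 2 of the 4 values shown sit.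

From the compounds shown here alone, whether a plain phenyl, with the remaining chloro also gone, would read higher or lower stays open. So does the effect on this number of an amine or a carboxylic acid on that ring.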